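This account rests on a few compounds, and the source may have more. Where it says the series, first, only, none or still open, it means among the compounds named here.

Compound 2 `O=C1Nc2ccccc2/C1=C\c1c(Cl)n(CCCc2ccccc2)c2ccccc12` sits at the high end of the three numbers obtained so far in a functional assay on cells (Leukemia cell, Homo sapiens) for cytotoxicity, with a stated time of 48 h; a higher number here means a weaker inhibitor of growth, a lower number a stronger inhibitor of growth. In this assay compound 2 gives 8910 nM, whereas compound 1 `O=C1Nc2ccccc2/C1=C\c1c(Cl)n(Cc2ccccc2)c2ccccc12` gives 3630 nM and compound 3 `COc1ccc2c(c1)/C(=C\c1c(Cl)n(Cc3cc(OC)c(OC)c(OC)c3)c3cc(C)c(OC)cc13)C(=O)N2` gives 6170 nM; the gap between compound 2 and compound 3 lies within the scatter, while the step of a 2.5-fold higher number from compound 1 to compound 2 (0.39 log units; beyond the scatter) lies beyond it. Compound 4 `O=C1Nc2ccc(Cl)cc2/C1=C\c1c(Cl)n(CCCc2ccccc2)c2ccccc12` differs from compound 2 by chloro in place of hydrogen on an aromatic carbon. For the measured compounds named here, none of the measured steps concerns a substituent on this ring: the only single-point step, from compound 1 to compound 2, changes the chain on the nitrogen and was modest, and compound 3 differs from the others in several places at once, so its value alone says nothing about a chloro here. Going by the values given here, with no bearing step to draw on, no change beyond the scatter is expected for compound 4, so that a 1.2-fold lower number from compound 2 to compound 4 (0.07 log units; within the scatter) is the estimated step. Compound 4 is therefore expected to give 7500 nM in this assay, with a range from 3000 nM to 20000 nM.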

Compound 4, concentration for 50% growth inhibition: 2880 nM
Estimate against measurement, compound 4: 2.6-fold (0.42 log units) above; the whole stated range lies above it.
By their numbers in this assay, from the lowest: compounds 4, 1, 3 and 2 (each within the scatter of the next, the first and the last beyond it).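

In this assay, chloro in place of hydrogen gives a 3.1-fold lower number from compound 2 to compound 4 (0.49 log units; beyond the scatter), the first single-place change shown on this six-membered aromatic ring, so a substituent at this carbon can shift the growth-inhibition number beyond the scatter. The step is modest and runs towards a stronger inhibitor of growth, the opposite direction to a 2.5-fold higher number from compound 1 to compound 2 (0.39 log units; beyond the scatter), which concerns the chain on the nitrogen rather than this ring. No evidence is available to explain what lies behind the step.

The compounds shown leave open whether a bromo, a nitrile or an amine at this same carbon would give a step of similar size or direction. They also leave open whether chloro here would give a comparable step with the chain of compound 1 on the nitrogen.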